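This account rests on a few compounds, and the source may have more. Where it says the series, first, only, none or still open, it means among the compounds named here.

Two members of the series have so far been run in an assay on membranes from HeLa cells for displacement of a labelled ligand from adenosine receptor A3 (Homo sapiens), read by scintillation counting, with a stated time of 180 min, tested at 1 uM; a higher number here means more inhibition at the concentration tested (going by the name of the read-out), a lower number less inhibition. Compound 1 `CCCC(=O)C1=C(C)NC(=O)NC1c1ccsc1` gives 1% in this assay. Compound 2 `CC1=C(c2ncc(C)o2)C(c2ccoc2)NC(=O)N1` gives 1% in this assay. Compound 2 stands level with compound 1 at the digits recorded; the two values lie within the scatter of each other, and nothing separates them. Both measured members sit at the floor of the read-out at the concentration tested.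

Compound 3 `CC1=C(c2ncc(C)o2)C(c2ccsc2)NC(=O)N1` is the next member and has not yet been run. It differs from compound 2 in one place: thiophen-3-yl in place of furan-3-yl on a saturated ring carbon. Among the compounds with values here, no step between measured compounds is available to size this change, and both values known so far sit at the floor. The expected step of a number 1 percentage points higher from compound 2 to compound 3 (within the scatter) is therefore none beyond the scatter. Compound 3 is estimated at 2% in this assay, with a range from -8% to 12%.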

Compound 3, a percentage reported as inhibition, at one concentration (the size of the read-out at that concentration, not a potency): 2%
Compound 3: middle estimate and measured number agree at the digits printed; low and high end bracket the measured number.
By their numbers in this assay, from the lowest: compounds 1, 2 and 3 (each within the scatter of the next).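

In this assay, the saturated ring carbon now has its first sized swap, with a number 1 percentage points higher from compound 2 to compound 3 (within the scatter) on going to thiophen-3-yl in place of furan-3-yl. The double-bonded ring carbon also has its first sized swap, with a number 1 percentage points higher from compound 1 to compound 3 (within the scatter) for 5-methyl-1,3-oxazol-2-yl in place of propylcarbonyl, so neither change separates the compounds and all three readings stay at the floor of the read-out. Nothing available accounts for these readings.

With every reading at the floor, these compounds do not show whether either position can affect the read-out at all at the concentration tested. Going by these compounds, it remains open whether a phenyl ring on the saturated ring carbon, or a carboxylic acid or longer alkyl chain on the double-bonded ring carbon, would lift the reading off the floor.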